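Trimming the Trifluoromethyl: Compound 1 to Compound 3

This account rests on a few compounds, and the source may have more. Where it says the series, first, only, none or still open, it means among the compounds named here.

Compound 1 `O=c1ccc(-c2ccc3cn[nH]c3c2)cn1Cc1cccc(C(F)(F)F)c1` was tested in an assay for inhibition of MAP kinase-interacting serine/threonine-protein kinase 2 (Homo sapiens), read by luminescence and ADP-Glo, with a stated time of 2 h (a lower number here means a stronger inhibitor, a higher number a weaker inhibitor), and gives 32 nM. Among the two numbers recorded so far, compound 1 stands highest; its only neighbour is compound 2 `Nc1n[nH]c2cc(-c3ccc(=O)n(Cc4cccc(C(F)(F)F)c4)c3)ccc12`, which in this assay gives 21 nM. Among the measured compounds shown here, the step of a 1.5-fold lower number from compound 1 to compound 2 (0.18 log units; within the scatter) is the single measured comparison available, and it lies within the scatter.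

Compound 3 `O=c1ccc(-c2ccc3cn[nH]c3c2)cn1Cc1cccc(F)c1` differs from compound 1 by the change (fluoro in place of trifluoromethyl on an aromatic carbon). For the measured compounds named here, no measured step touches this group: the one step known, from compound 1 to compound 2, concerns an amino group on another part of the shared core and does not speak to the benzyl substituent. The expectation for this assay therefore rests on the shared core alone and carries wide uncertainty. The step of a 1.9-fold higher number from compound 1 to compound 3 (0.27 log units; within the scatter) is expected to be modest and, if anything, toward a higher number. Compound 3 is estimated at 60 nM, with a range from 20 nM to 200 nM.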

Compound 3, half-maximal inhibitory concentration: 38 nM
The estimate for compound 3 lay 1.6-fold (0.20 log units) above the measured number; low and high end bracket the measured number.
By their numbers in this assay, from the lowest: compounds 2, 1 and 3 (each within the scatter of the next).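

In this assay, among the compounds shown here, the step of a 1.2-fold higher number from compound 1 to compound 3 (0.07 log units; within the scatter) is the first reading at this position, on an aromatic carbon of a six-membered aromatic ring of carbon only, meta to a large group. The change takes the substituent there from trifluoromethyl, with 4 heavy atoms, to fluoro, with 1 heavy atom, and for this pair that reduction leaves a difference that cannot be told from repeat measurement. Nothing at hand gives a measured reason for this outcome, so the result stands as a comparison of two numbers only.

Both groups compared count no hydrogen-bond donors and no hydrogen-bond acceptors, so the compounds shown leave open how a hydroxyl group, a carboxylic acid or a longer chain such as ethoxy would read at this place. They also leave open whether the amino group of compound 2, which sits on another part of the shared core, and the fluoro of compound 3 would give a different number when carried together in one compound.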